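Swapping the Urea of Compound 2 for an Amide

The compounds below may be only part of what the source reports. "The series", "measured", "known", "first", "only" and "open" are said of these compounds alone.

Of the compounds shown here, three have been measured in a functional assay on MDA-MB-231 cells (Homo sapiens) for cytotoxicity, read by MTT assay, with a stated time of 48 h; on this read-out higher numbers stand for weaker inhibition and lower numbers for stronger inhibition. Compound 1 `O=C(OCCCC(c1ccc(F)cc1)c1ccc(F)cc1)c1cc(Cl)c(OCc2ccccc2)c(Cl)c1` gives > 20000 nM, which is a limit of the assay and not a number. Compound 2 `Cc1ccc(NC(=O)NCCCCC(c2ccc(F)cc2)c2ccc(F)cc2)cc1` gives > 20000 nM, also a limit rather than a number. Compound 3 `Nc1ccc(C(CCCCNC(=O)Nc2ccc(Cl)c(C(F)(F)F)c2)c2ccc(N)cc2)cc1` gives 12200 nM.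

Compound 2 therefore stands on a limit, and it shares that position with one further compound, as the limit of > 20000 nM in this assay, at which 2 of the 3 values shown sit, shows. Among the compounds with values here, the single real number among the three belongs to compound 3, and that number is itself a weak inhibition.

Compound 4 `O=C(NCCCCC(c1ccc(F)cc1)c1ccc(F)cc1)c1ccc(Cl)c(C(F)(F)F)c1` is not yet measured. It differs from compound 2 in one place: 4-chloro-3-(trifluoromethyl)phenyl in place of (4-methylphenyl)amino on a carbonyl carbon. In plain terms the urea of compound 2 becomes an amide, and the aryl group that enters is the same 4-chloro-3-(trifluoromethyl)phenyl that compound 3 carries.

Within the data shown here, no step between measured compounds is available to anchor this change, and compound 2 itself offers only a limit. Compound 3, with that same aryl group, gives 12200 nM, so compound 4 is expected to land in the same weak region. For compound 4 a result that is again a limit of the assay remains quite possible. Compound 4 is expected to give about 15000 nM, with a range from 4000 nM to 40000 nM. Counted from the limit of compound 2, the expected step is an at least 1.3-fold lower number from compound 2 to compound 4 (0.12 log units; that floor lies within the scatter), a small move, if any, toward stronger inhibition.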

Compound 4, half-maximal inhibitory concentration: 11700 nM
For compound 4 the middle estimate is 1.3-fold (0.11 log units) above the measured one; the measured number falls inside the stated range.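

In this assay compound 4 gives 11700 nM, so replacing (4-methylphenyl)amino with 4-chloro-3-(trifluoromethyl)phenyl on this carbonyl carbon yields a real number on the core of compound 2, although still a high one that stands for weak inhibition. Compound 2 remains a limit of the assay and not a number, so the comparison has only a floor: the limit of > 20000 nM in this assay, at which 2 of the 4 values shown sit. Going by these compounds, the change gives an at least 1.7-fold lower number from compound 2 to compound 4 (0.23 log units; that floor lies within the scatter), which means that the true size of the step is unknown and that the printed floor alone does not establish a real gain.

This single change also turns a urea into an amide, removing one hydrogen-bond donor while adding chlorine and trifluoromethyl, so the compounds shown cannot tell which part of the swap matters. Also open, on these data alone, is whether a nitrile or a carboxylic acid in place of the trifluoromethyl on this aryl ring would bring the number in this assay down further or send it back to the limit.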